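The source may hold more compounds than are shown below. What is called first, only, known or untested is meant among the compounds shown, and "the series" means these compounds.

Working notes on the series. Among the compounds with values here, in a physicochemical assay for solubility, measured as kinetic solubility, with a stated time of 1 h, at pH 7.4 (on this read-out lower numbers stand for lower solubility and higher numbers for higher solubility), compound 1 `CC(=O)N[C@@H](C)C(=O)NC1=NN(c2ccc(Cl)c(Cl)c2)CC1` gives 58000 nM and compound 2 `O=C(NC1=NN(c2ccc(Cl)c(Cl)c2)CC1)c1ccnnc1` gives 23000 nM, the lower of the two numbers so far. Within the data shown here, compound 3 `O=C(NC1=NN(c2ccc(Cl)c(Cl)c2)CC1)c1cccnc1F` keeps the shared core and has no measurement yet. The change is 2-fluoropyridin-3-yl in place of pyridazin-4-yl on a carbonyl carbon.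

Among the measured compounds shown here, one measured step bears on this, at the same place on a carbonyl carbon: a 2.5-fold lower number from compound 1 to compound 2 (0.40 log units; beyond the scatter). That step is modest, and it is a single comparison involving a different departing group, so it suggests a size more firmly than a direction. For the measured compounds named here, no measured compound yet carries 2-fluoropyridin-3-yl. A modest step of similar size is therefore expected in this assay, toward a lower number, although a result within the scatter of compound 2 remains possible. The expected change is a 2.3-fold lower number from compound 2 to compound 3 (0.36 log units; beyond the scatter). Compound 3 is estimated at 10000 nM, with an expected range from 3000 nM to 25000 nM.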

Compound 3, solubility: 13000 nM
Compound 3: middle estimate off by 1.3-fold (0.11 log units), on the low side, and the stated range covers the measured number.
By their numbers in this assay, from the lowest: compounds 3 and 2 (each within the scatter of the next); then compound 1.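

In this assay the replacement of pyridazin-4-yl by 2-fluoropyridin-3-yl on the carbonyl carbon gives a 1.8-fold lower number from compound 2 to compound 3 (0.25 log units; within the scatter) and so does not separate these two aromatic groups, even though the entering group brings a fluorine and a different count of ring hetero atoms and hydrogen-bond acceptors. Against the 1-acetamidoethyl group of compound 1, the same position gives a 4.5-fold lower number from compound 1 to compound 3 (0.65 log units; beyond the scatter), so compound 2 and compound 3 both stand apart from compound 1 in the same direction, and none of the three compounds goes against this. No measurement shown accounts for these numbers.

The compounds shown leave open how much of the gap from compound 1 follows the aromatic ring itself and how much follows the loss of the 1-acetamidoethyl chain, as only one such chain appears at this position. Also open, on these data alone, are the plain pyridin-3-yl group, which would isolate the fluorine, and an aminomethyl group or a carboxylic acid on the same carbonyl carbon, any of which could show how far the numbers at this position can move.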